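Sulfur oxidation state on a shared core: compound 4 expected

The compounds below may be only part of what the source reports. "The series", "measured", "known", "first", "only" and "open" are said of these compounds alone.

Measured compounds:
compound 1 `CSc1ccc2c(c1)c(O)c(C(=O)N(C)c1ccccc1)c(=O)n2C` with 100%
compound 2 `CN(C(=O)c1c(O)c2cc(Sc3ccccc3)ccc2n(C)c1=O)c1ccccc1` with 100%
compound 3 `CN(C(=O)c1c(O)c2cc([S+](C)[O-])ccc2n(C)c1=O)c1ccccc1` with 100%

These three compounds were examined in a functional assay on the whole organism for inhibition, with Mus musculus as the target, at a dose of 32 mg/kg by the oral route; on this read-out higher numbers stand for more inhibition at the one dose given (going by the name of the read-out) and lower numbers for less inhibition. Compound 3 stands level with compounds 1 and 2 at the digits reported: the step of no change at the digits printed from compound 1 to compound 3 (within the scatter) and the step of no change at the digits printed from compound 2 to compound 3 (within the scatter) both lie within the scatter, as does no change at the digits printed from compound 1 to compound 2 (within the scatter), so nothing separates the three on this read-out.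

Compound 4 `CN(C(=O)c1c(O)c2cc(S(C)(=O)=O)ccc2n(C)c1=O)c1ccccc1` has not yet been measured in this assay. It differs from compound 3 in one place: a group of 4 heavy atoms (1 carbon, 2 oxygen, 1 sulfur; no ring) in place of a group of 3 heavy atoms (1 carbon, 1 oxygen, 1 sulfur; no ring), on an aromatic carbon. For the measured compounds named here, the steps that bear on this change are those that also replaced the group on the same aromatic carbon, no change at the digits printed from compound 1 to compound 3 (within the scatter) and no change at the digits printed from compound 2 to compound 3 (within the scatter), and neither moved the read-out beyond the scatter. The methylsulfonyl group is a further change at that carbon, and on the data shown no step at that position has altered the read-out, so no change beyond the scatter is expected from compound 3 to compound 4, that is a number 2 percentage points lower from compound 3 to compound 4 (within the scatter). Compound 4 is therefore estimated at 98%, with a range from 85% to 100%.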

Compound 4, a percentage reported as inhibition, in the whole organism at one dose (the size of the read-out at that dose, not a potency): 0%
Compound 4: the middle estimate sits 98 percentage points above what was measured; the whole stated range lies above it.
By their numbers in this assay, from the lowest: compound 4; then compounds 1, 2 and 3 (each within the scatter of the next).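

In this assay, for the compounds shown here, methylsulfonyl is the first group on this aromatic carbon to separate from the others: replacing the group of compound 3 gives a number 100 percentage points lower from compound 3 to compound 4 (beyond the scatter), replacing phenylsulfanyl gives a number 100 percentage points lower from compound 2 to compound 4 (beyond the scatter), and replacing methylsulfanyl gives a number 100 percentage points lower from compound 1 to compound 4 (beyond the scatter). The position therefore does not accept every sulfur-bearing group, and the difference of a single oxygen between the groups of compound 3 and compound 4 is enough to separate a full read-out from none. Nothing available explains this loss.

The compounds shown leave open whether the loss is confined to methylsulfonyl or extends to other groups on this carbon, such as a carboxylic acid, an amine or a sulfonamide. They also leave open how compounds 1, 2 and 3 compare at lower doses.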